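Swapping an Amide Substituent on a Second Core

This account rests on a few compounds, and the source may have more. Where it says the series, first, only, none or still open, it means among the compounds named here.

Of the compounds shown here, three have been tested in an assay on isolated protein for inhibition of MAP kinase-interacting serine/threonine-protein kinase 2 (Homo sapiens), read by HTRF, in the presence of a further agent that is not named here; on this read-out lower numbers stand for stronger inhibition and higher numbers for weaker inhibition. Compound 1 `CCCNC(=O)c1cccc(C#Cc2ccccc2Nc2ncnc3ccc(Cl)nc23)c1` gives 3900 nM, and compound 2 `O=C(c1cccc(C#Cc2ccccc2Nc2ncnc3ccc(Cl)nc23)c1)N1CCNCC1` gives 5000 nM. The two share one core and differ in one place: propylamino in place of piperazin-1-yl on a carbonyl carbon. That change produced a 1.3-fold lower number from compound 2 to compound 1 (0.11 log units; within the scatter), so the two numbers cannot be told apart with confidence.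

Compound 3 `Cc1c(C(=O)N2CCNCC2)oc2ccc(Nc3ncnc4ccc(Cl)nc34)cc12` is built on a different core and gives 1900 nM, the lowest of the three numbers; how its core differs from that of compound 2 is not broken down here.

Compound 4 `CCCNC(=O)c1oc2ccc(Nc3ncnc4ccc(Cl)nc34)cc2c1C` has not yet been measured in this assay . It relates to compound 3 exactly as compound 1 relates to compound 2: propylamino in place of piperazin-1-yl on a carbonyl carbon. Since the same change made a step within the scatter between compound 2 and compound 1, the expectation is that compound 4 will stay close to compound 3, with an estimated step of a 1.2-fold lower number from compound 3 to compound 4 (0.07 log units; within the scatter). On that basis compound 4 is expected to give about 1600 nM in this assay , plausibly between 700 nM and 3500 nM.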

Compound 4, half-maximal inhibitory concentration: 1900 nM
The estimate for compound 4 lay 1.2-fold (0.07 log units) below the measured number, and the stated range covers the measured number.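

In this assay, going by these compounds alone, propylamino in place of piperazin-1-yl on a carbonyl carbon gives no change at the digits printed from compound 3 to compound 4 (within the scatter), so on the second core this change again produces no step that can be told from the scatter. Set side by side, the two results agree: the same change on two cores in this assay, a 1.3-fold lower number (0.11 log units; within the scatter) from compound 2 to compound 1 and no change at the digits printed (within the scatter) from compound 3 to compound 4, 1.3-fold (0.11 log units) apart, within the scatter of two such steps. This shows that, on these two cores, the change carried over as a step too small to read, but it does not show that the two groups would remain interchangeable on a third core, and two pairs are too few to establish a rule for the series.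

The compounds shown leave open whether any other group on this carbonyl carbon, such as a longer chain like hexylamino or a ring like morpholin-4-yl, would move the number on either core. They also leave open whether a carboxylic acid in place of either amide would produce a step beyond the scatter.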